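This account rests on a few compounds, and the source may have more. Where it says the series, first, only, none or still open, it means among the compounds named here.

Compound 1 `CC1=CC[C@@H]([C@@](C)(O)CCCC(C)(C)NC(=S)NN)CC1` and compound 2 `CC1=CC[C@@H]([C@@](C)(O)CCCC(C)(C)NC(=S)N/N=C\c2ccccc2)CC1` share the same core and differ only at one nitrogen. In a functional assay on MCF7 cells (Homo sapiens) for cytotoxicity, read by sulforhodamine B assay (on this read-out higher numbers stand for lower toxicity in this test and lower numbers for higher toxicity in this test), compound 1 gives > 100000 nM, which is a limit of the test rather than a number. In this assay, going by the values given here, compound 2 gives 60400 nM, the only plain number measured so far. The step of an at least 1.6-fold lower number from compound 1 to compound 2 (0.21 log units; that floor lies within the scatter) comes from a group of 8 heavy atoms in place of one nitrogen atom on an amide-type nitrogen, and its floor lies within the usual scatter. Compound 3 `CC1=CC[C@@H]([C@@](C)(O)CCCC(C)(C)NC(=S)N/N=C\c2ccc(C)cc2)CC1` carries the change (methyl in place of hydrogen on an aromatic carbon), on an aromatic carbon of a six-membered aromatic ring of carbon only. Among the compounds with values here, no measured step touches this ring, so nothing here points to a shift beyond the scatter in either direction. Compound 3 is therefore expected to give about 50000 nM, within 20000 nM to 150000 nM, which would mean an expected step of a 1.2-fold lower number from compound 2 to compound 3 (0.08 log units; within the scatter).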

Compound 3, concentration lethal to 50% of the cells: > 100000 nM
Compound 3 was reported as a limit (the forecaster's own chance of this, stated with the estimate: 25%); middle value at least 2.0-fold (0.30 log units) from the limit.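

Going by these compounds alone, this is the first measured change on the aromatic ring: in this assay, going from phenyl to 4-methylphenyl gives an at least 1.6-fold higher number from compound 2 to compound 3 (0.21 log units; that floor lies within the scatter). From the compounds shown here alone, the result for compound 3 is a limit of the test rather than a number, so the true size of that step stays unknown, and the step linking compound 1 to compound 3 cannot be read. Compound 2 remains the only compound with a plain number, and adding a single methyl group is enough to take the reading back to the limit: the limit of > 100000 nM in this assay, at which 2 of the 3 values shown sit.

Still open, going by these compounds, is whether another group at the same place on the ring, such as a chlorine atom, a methoxy group or an amine, would give a plain number to compare with compound 2. Also open, on these data alone, is what a pyridine ring in place of the phenyl ring would do.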